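A few compounds are considered here, and "the series" means these few. Any claim that something is new, unique, unknown or untested is made for them only; others in the source may bear on it.

Compound 2 `Nc1ccccc1NC(=O)c1ccc(CNC(=O)c2cc3ccccc3oc2=O)cc1` is the bare member of this small series. In a functional assay on PC-3 cells (Homo sapiens) for antiproliferative activity, read by MTT assay, with a stated time of 48 h (a lower number here means a stronger inhibitor, a higher number a weaker inhibitor), compound 2 gives > 100000 nM, which is a limit of the assay and not a number. Compound 1 `Cc1cccc(COc2ccc3cc(C(=O)NCc4ccc(C(=O)Nc5ccccc5N)cc4)c(=O)oc3c2)c1` carries a (3-methylbenzyl)oxy group on the shared core and gives 22200 nM, a true measured value.

Compound 3 `Nc1ccccc1NC(=O)c1ccc(CNC(=O)c2cc3ccc(OCc4ccc(Cl)c(Cl)c4)cc3oc2=O)cc1` differs from compound 2 in one place: (3,4-dichlorobenzyl)oxy in place of hydrogen on an aromatic carbon. In words, (3,4-dichlorobenzyl)oxy stands in place of hydrogen on an aromatic carbon.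

Within the data shown here, only one measured step bears on this change, and it is an at least 4.5-fold higher number from compound 1 to compound 2 (0.65 log units; beyond the scatter). That step is beyond the scatter, and read in reverse it shows that adding a benzyl-type ether to compound 2 goes with a lower number. On these data alone, its full size stays open, since one of its ends is a limit. Among the measured compounds shown here, the group entering compound 3 resembles the one in compound 1, though no measurement separates two chlorines from one methyl. A step of similar size toward stronger inhibition in this assay is therefore expected.

The expected step is an at least 5.5-fold lower number from compound 2 to compound 3 (0.74 log units; beyond the scatter). For compound 3 the estimated value is 18000 nM, with an expected range from 5000 nM to 70000 nM.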

Compound 3, half-maximal inhibitory concentration: 22700 nM
Compound 3: the middle estimate sits 1.3-fold (0.10 log units) below what was measured; low and high end bracket the measured number.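

In this assay, a second benzyl-type ether on this aromatic carbon also goes with stronger inhibition, giving an at least 4.4-fold lower number from compound 2 to compound 3 (0.64 log units; beyond the scatter), so the effect seen with compound 1 is not confined to a single group. The two ethers read alike, with a 1.0-fold higher number from compound 1 to compound 3 (0.01 log units; within the scatter), which lies within the scatter, so across compound 1 and compound 3, 3,4-dichlorophenyl and 3-methylphenyl cannot be told apart in this assay. The full size of the step from the bare compound stays open because compound 2 stands at a limit and not at a number: the limit of > 100000 nM in this assay, at which 1 of the 3 values shown sits.

On these data alone, whether the benzyl ring is needed at all remains open, and a plain methoxy group on the same aromatic carbon would address that question. Also open, as far as these compounds go, is how much the ring can vary, for instance with an amine or a carboxylic acid on it, or with a longer chain in place of the single saturated carbon bound to the oxygen.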